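A few compounds are considered here, and "the series" means these few. Any claim that something is new, unique, unknown or untested is made for them only; others in the source may bear on it.

Measured so far:
- compound 1 `CCCCCCCC(=O)OCCc1c(-c2ccccc2Cl)c2cc(Cl)ccc2[nH]c1=O`: 78000 nM
- compound 2 `COCC(=O)OCCc1c(-c2ccccc2Cl)c2cc(Cl)ccc2[nH]c1=O`: 74000 nM
- compound 3 `CC(=O)OCC(=O)OCCc1c(-c2ccccc2Cl)c2cc(Cl)ccc2[nH]c1=O`: 100000 nM

In an ADME assay on HepG2 2.2.15 cells (Homo sapiens) for cytotoxicity (on this read-out lower numbers stand for higher toxicity in this test and higher numbers for lower toxicity in this test), compound 3 gives 100000 nM, within the scatter of both other compounds. The next compound, compound 4 `O=C(CCC1CCCCC1)OCCc1c(-c2ccccc2Cl)c2cc(Cl)ccc2[nH]c1=O`, has cyclohexylmethyl in place of acetoxy on a saturated chain carbon bound to a carbonyl carbon. The closest measured change swaps hexyl, also made of carbon only, for acetoxy at that place, giving a 1.3-fold higher number from compound 1 to compound 3 (0.11 log units; within the scatter). The remaining steps, a 1.1-fold lower number from compound 1 to compound 2 (0.02 log units; within the scatter) and a 1.4-fold higher number from compound 2 to compound 3 (0.13 log units; within the scatter), also stay within the scatter. No step beyond the scatter is therefore expected, and the estimate is a 1.3-fold lower number from compound 3 to compound 4 (0.12 log units; within the scatter). For compound 4 the estimated value is 75000 nM, with an expected range of 38000 nM to 140000 nM.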

Compound 4, half-maximal cytotoxic concentration: 160000 nM
For compound 4 the middle estimate is 2.1-fold (0.33 log units) below the measured one, and the stated range ends below it.
By their numbers in this assay, from the lowest: compounds 2, 1, 3 and 4 (each within the scatter of the next, the first and the last beyond it).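

In this assay, among the compounds shown here, cyclohexyl in place of pentyl gives a 2.1-fold higher number from compound 1 to compound 4 (0.31 log units; beyond the scatter) and cyclohexylmethyl in place of methoxy gives a 2.2-fold higher number from compound 2 to compound 4 (0.33 log units; beyond the scatter) and these are the first steps beyond the scatter at this place, though both are modest. Cyclohexylmethyl in place of acetoxy gives a 1.6-fold higher number from compound 3 to compound 4 (0.20 log units; within the scatter) and stays within the scatter, so the ring-bearing chain separates from the hexyl and methoxy compounds only. Nothing measured here explains why a ring on this chain raises the number. From the compounds shown here alone, whether an amine or a carboxylic acid at this place would shift the number further remains open. So does whether a phenyl ring would match cyclohexyl.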